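Azido for ((Trifluoromethyl)carbonyl)amino: Expected Microsomal Stability

The source may hold more compounds than are shown below. What is called first, only, known or untested is meant among the compounds shown, and "the series" means these compounds.

Compound 1 `CC(=O)N[C@@H]1CCN(c2cc(C)nn3c(-c4cccc(S(=O)(=O)N(C)C)c4)c(C)nc23)C1`: > 95%
Compound 2 `COc1ccc(-c2c(C)nc3c(N4CC[C@@H](NC(=O)C(F)(F)F)C4)cc(C)nn23)cc1OC`: > 95%

Both values above come from an ADME assay on microsomes from liver (Homo sapiens) for metabolic stability, read by LC-MS, with NADPH named in the record, with a stated time of 60 min, tested at 1 uM, in the absence of a further agent (on this read-out lower numbers stand for a less stable compound and higher numbers for a more stable compound), and both are limits of the assay rather than numbers. Compound 1 gives > 95% in this assay, a limit. Compound 2 gives > 95% in this assay, again a limit. Compound 2 therefore stands at the boundary described by the limit of > 95% in this assay, at which 2 of the 2 values shown sit, and no measured value separates it from compound 1.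

Compound 3 `COc1ccc(-c2c(C)nc3c(N4CC[C@@H](N=[N+]=[N-])C4)cc(C)nn23)cc1OC` has not yet been measured in this assay. It differs from compound 2 in one place: azido in place of ((trifluoromethyl)carbonyl)amino on a saturated ring carbon. Within the data shown here, no step between two measured compounds is available, so the size of this change in this assay cannot be read from a measured pair. Compound 3 is expected to show a step of a number at least 3 percentage points lower from compound 2 to compound 3 (that floor lies within the scatter) that stays within the scatter. The estimate for compound 3 in this assay is 92%, with a range from 78% to 99%.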

Compound 3, percent of the compound remaining: > 95%
Compound 3: no number, only a limit (the forecaster's own chance of this, stated with the estimate: 55%); at least 3 percentage points between middle value and limit.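

No step from compound 2 to compound 3 can be read in this assay, as both values are limits of the assay: the limit of > 95% in this assay, at which 3 of the 3 values shown sit.

The compounds shown leave open how far the percent of compound remaining would differ between ((trifluoromethyl)carbonyl)amino and azido on the saturated ring carbon.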